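Cytotoxicity in the series; pyridin-4-yl on the ring nitrogen

This account rests on a few compounds, and the source may have more. Where it says the series, first, only, none or still open, it means among the compounds named here.

Measured compounds:
compound 1 `CS(=O)(=O)CCCn1c(Cn2c(=O)n(C3CC3)c3ccncc32)cc2cc(Cl)ccc21` — in an ADME assay on HeLa cells (Homo sapiens) for cytotoxicity, read by ATP content, with a stated time of 3 days (on this read-out higher numbers stand for lower toxicity in this test and lower numbers for higher toxicity in this test), compound 1 gives > 50000 nM, which is a limit of the assay.
compound 2 `N#CCCCn1c(Cn2c(=O)n(-c3ccncc3F)c3ccncc32)cc2cc(Cl)ccc21` — in this assay compound 2 gives > 50000 nM, a limit.
compound 3 `N#CCCCn1c(Cn2c(=O)n(C3CC3)c3ccncc32)cc2cc(Cl)ccc21` — in this assay compound 3 gives > 50000 nM, again a limit.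

Compound 3 therefore stands only at a limit, and so do the two other compounds shown; all three sit at the same point, (the limit of > 50000 nM in this assay, at which 3 of the 3 values shown sit). The two steps that lead into compound 3 are a step that the two limits leave unreadable from compound 1 to compound 3 and a step that the two limits leave unreadable from compound 2 to compound 3; both are unreadable in size, as every value on either side is a limit.

The new compound 4 `N#CCCCn1c(Cn2c(=O)n(-c3ccncc3)c3ccncc32)cc2cc(Cl)ccc21` differs from compound 3 by pyridin-4-yl in place of cyclopropyl on an aromatic nitrogen. The closest measured analogue is compound 2, which carries 3-fluoropyridin-4-yl on the same aromatic nitrogen and sits at the limit; the cyclopropyl compounds 1 and 3 sit there too. For the measured compounds named here, no measured step gives a readable size, so no step beyond the scatter in this assay can be expected in either direction; the expected step from compound 3 to compound 4 is a step that the limit leaves unreadable from compound 3 to compound 4. Compound 4 is estimated at 60000 nM, range 30000 nM to 150000 nM, and is expected most likely to be reported again only as a limit.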

Compound 4, half-maximal cytotoxic concentration: > 50000 nM
Compound 4: no number, only a limit; the forecaster's own chance of this, stated with the estimate: 85%; the middle value lies beyond the limit too.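

In this assay neither step into compound 4, from compound 3 or from compound 2, can be read, as the values on both sides are limits and not numbers: the limit of > 50000 nM in this assay, at which 4 of the 4 values shown sit. The compounds shown leave open at what concentration any of the four reaches half-maximal cytotoxicity, and whether any of these changes shifts it.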